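Removing the Trifluoromethyl Group: Expected Loss of Potency

This account rests on a few compounds, and the source may have more. Where it says the series, first, only, none or still open, it means among the compounds named here.

Within the data shown here, compound 3 `CC(C)c1ccc(-c2nc(SCc3cn(CC(=O)NC(=O)Nc4ccccn4)nn3)nc(Nc3cccc(C(F)(F)F)c3)c2C#N)cc1` is the only one of three compounds with a readable number in a functional assay on MCF7 cells (Homo sapiens) for inhibition, read by MTT assay, with a stated time of 72 h; on this read-out lower numbers stand for stronger inhibition and higher numbers for weaker inhibition: in this assay compound 3 gives 8620 nM. Compound 1 `CC(C)c1ccc(-c2nc(SCc3cn(CC(=O)NC(=O)Nc4ccccn4)nn3)nc(Nc3ccc(F)cc3)c2C#N)cc1` gives only a limit of the assay, > 64000 nM. Compound 2 `CC(C)c1ccc(-c2nc(SCc3cn(CC(=O)NC(=O)Nc4ccccn4)nn3)nc(Nc3ccc(Cl)cc3)c2C#N)cc1` likewise gives only a limit, > 64000 nM. The step that the two limits leave unreadable from compound 1 to compound 2 therefore cannot be read. Compound 4 `CC(C)c1ccc(-c2nc(SCc3cn(CC(=O)NC(=O)Nc4ccccn4)nn3)nc(Nc3ccccc3)c2C#N)cc1` has not yet been measured; it differs from compound 3 by hydrogen in place of trifluoromethyl on an aromatic carbon.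

Among the measured compounds shown here, two measured steps bear on this change. an at least 7.4-fold lower number from compound 1 to compound 3 (0.87 log units; beyond the scatter) and an at least 7.4-fold lower number from compound 2 to compound 3 (0.87 log units; beyond the scatter) both show that the 3-(trifluoromethyl)phenyl group goes with a lower number than 4-fluorophenyl or 4-chlorophenyl, though with both starting points sitting at the limit of > 64000 nM in this assay, at which 2 of the 3 values shown sit, the true size stays unknown. For the measured compounds named here, compound 4 drops the trifluoromethyl entirely, leaving phenyl; the data hold no compound with plain phenyl, so the expectation rests on that direction alone. The expected step is a 4.6-fold higher number from compound 3 to compound 4 (0.67 log units; beyond the scatter), a move toward weaker inhibition. Compound 4 is therefore estimated at 40000 nM, with a range from 12000 nM to 64000 nM, and a real chance that only a limit is returned.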

Compound 4, half-maximal inhibitory concentration: > 64000 nM
Compound 4 was reported as a limit (the forecaster's own chance of this, stated with the estimate: 45%); middle value at least 1.6-fold (0.20 log units) away from the limit.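

Among these compounds, replacing trifluoromethyl with hydrogen on the aromatic ring gives an at least 7.4-fold higher number from compound 3 to compound 4 (0.87 log units; beyond the scatter), and this is the first step in which nothing else changes. The earlier steps shown here replaced 4-fluorophenyl or 4-chlorophenyl with 3-(trifluoromethyl)phenyl, so the group and its place on the ring changed together, whereas this step ties the readable number of compound 3 to the trifluoromethyl group itself. The steps among compound 1, compound 2 and compound 4 cannot be read, and phenyl, 4-fluorophenyl and 4-chlorophenyl cannot be ranked, because all three compounds return a limit of the assay rather than a number: the limit of > 64000 nM in this assay, at which 3 of the 4 values shown sit.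

The true size of the loss stays unknown, as does any difference among these three compounds at concentrations beyond that limit. On these data alone, it also remains open whether only trifluoromethyl gives a readable number at this place, or whether a methyl or methoxy group on the same carbon would do so too in this assay.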